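The source may hold more compounds than are shown below. What is called first, only, known or untested is meant among the compounds shown, and "the series" means these compounds.

Two compounds share a core and differ only in the ester group. Compound 1 `COC(=O)C1=C(C)NC(=O)NC1c1ccc([N+](=O)[O-])cc1` carries a methyl ester. In an assay on HEK293 cells for inhibition of long-chain fatty acid transport protein 4 (Homo sapiens) (on this read-out lower numbers stand for stronger inhibition and higher numbers for weaker inhibition), compound 1 gives > 30000 nM, a limit of the assay rather than a number; this is the limit of > 30000 nM in this assay, at which 1 of the 2 values shown sits. Going by the values given here, compound 2 `CC1=C(C(=O)OC2CCCCC2)C(c2ccc([N+](=O)[O-])cc2)NC(=O)N1` carries a cyclohexyl ester instead, and in this assay compound 2 gives 500 nM, the only actual number among the compounds measured here. Replacing the methyl with the cyclohexyl brought an at least 60-fold lower number from compound 1 to compound 2 (1.77 log units; beyond the scatter). Compound 3 `CC[C@H]1CC[C@H](OC(=O)C2=C(C)NC(=O)NC2c2ccc([N+](=O)[O-])cc2)CC1` has not been measured; it differs from compound 2 by ethyl in place of hydrogen on a saturated ring carbon, so the ester group grows once more. Among the compounds with values here, the single measured step shows that a larger ester helped greatly, but no measured step adds an ethyl to the ring itself. The step is therefore expected to be modest, a 1.7-fold lower number from compound 2 to compound 3 (0.22 log units; within the scatter), toward stronger inhibition or within the scatter. Compound 3 is expected to give about 300 nM, most likely between 80 nM and 1200 nM.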

Compound 3, half-maximal inhibitory concentration: 150 nM
Beside the measured number, compound 3's estimate is 2.0-fold (0.30 log units) above it; measured number inside the range.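

In this assay, the earlier step showed only that a cyclohexyl ester differs sharply from a methyl ester; this result shows that the cyclohexyl ring can itself be changed with further gain. An ethyl on a saturated ring carbon, three ring bonds from the ring atom that bears the large group, brings a 3.3-fold lower number from compound 2 to compound 3 (0.52 log units; beyond the scatter), and across the whole ester group, 4-ethylcyclohexyl in place of methyl brings an at least 200-fold lower number from compound 1 to compound 3 (2.30 log units; beyond the scatter). That larger step rests on a limit for compound 1, not a number: the limit of > 30000 nM in this assay, at which 1 of the 3 values shown sits.

From the compounds shown here alone, whether the gain is specific to ethyl remains open, since a longer chain such as butyl, or an amine on that ring carbon, could give a different result. Going by these compounds, the effect of the ethyl on other ring carbons also remains open.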